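Replacing 4-chlorophenyl with 2-(hydroxymethyl)phenyl in compound 3

The source may report more compounds than this note shows. Statements on the series, on what has been measured and on what is new or still open speak of the compounds shown alone.

Measured in a physicochemical assay for lipophilicity, read by HPLC, at pH 7.5; on this read-out higher numbers stand for higher lipophilicity and lower numbers for lower lipophilicity:
- compound 1 `CC[C@@H](Nc1c(C#N)c(-c2ccc(-c3ccccc3F)cc2)nc2cnccc12)C(N)=O`: 2.7
- compound 2 `CC[C@@H](Nc1c(C#N)c(-c2ccc(-c3cccc(C)c3F)cc2)nc2cnccc12)C(N)=O`: 3
- compound 3 `CC[C@@H](Nc1c(C#N)c(-c2ccc(-c3ccc(Cl)cc3)cc2)nc2cnccc12)C(N)=O`: 3.1

Compound 3 stands at 3.1. The series shows a number 0.10 log units higher from compound 2 to compound 3 (within the scatter), and also a number 0.40 log units higher from compound 1 to compound 3 (beyond the scatter), so it sits level with one neighbour and clear of the other. Compound 4 `CC[C@@H](Nc1c(C#N)c(-c2ccc(-c3ccccc3CO)cc2)nc2cnccc12)C(N)=O` carries a single change from compound 3: 2-(hydroxymethyl)phenyl in place of 4-chlorophenyl on an aromatic carbon. In words, 2-(hydroxymethyl)phenyl comes in place of 4-chlorophenyl on an aromatic carbon.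

Three measured steps offer some guidance, and all are small. One is a number 0.30 log units higher from compound 1 to compound 2 (within the scatter). The most relevant is a number 0.40 log units higher from compound 1 to compound 3 (beyond the scatter), since it also exchanges the group that leaves here, and it shows that compound 3 gains on compound 1 when 4-chlorophenyl is present. Among the measured compounds shown here, none of the measured compounds has a hydrogen-bond donor on this group, so the series cannot fix the size of the coming step. A fall is nevertheless expected, larger than any step seen so far, and the expected change is a number 0.90 log units lower from compound 3 to compound 4 (beyond the scatter). In this assay, the estimate for compound 4 is 2.2, with an expected range of 1.8 to 2.7.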

Compound 4, distribution coefficient: 2.1
Compound 4: the middle estimate sits 0.10 log units above what was measured; measured number inside the range.
By their numbers in this assay, from the lowest: compound 4; then compounds 1, 2 and 3 (each within the scatter of the next, the first and the last beyond it).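

In this assay, this position moved the read-out further than any earlier change: the series shows a number 1.00 log units lower from compound 3 to compound 4 (beyond the scatter) and a number 0.90 log units lower from compound 2 to compound 4 (beyond the scatter), so compound 4 falls clear of both compounds it had been expected to drop beneath. The comparison with the smallest change in structure is just as informative, since hydroxymethyl in place of fluoro still gives a number 0.60 log units lower from compound 1 to compound 4 (beyond the scatter), which places compound 4 lowest of the four, beyond the scatter from each of the others. Among the compounds shown here, this is the first compound here with a hydrogen-bond donor on this group, but nothing available accounts for the fall.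

The compounds shown cannot separate the contribution of the hydroxyl hydrogen from that of the oxygen or the added carbon, and a methoxymethyl group, which keeps the oxygen but replaces that hydrogen, would address this directly. On these data alone, how far the read-out would move with a longer hydroxyethyl chain, an amine or a carboxylic acid on this ring also remains open.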